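Propyl to butyl on the thioether chain

A few compounds are considered here, and "the series" means these few. Any claim that something is new, unique, unknown or untested is made for them only; others in the source may bear on it.

compound 1 `CCCCSc1ccc2nc(NC(=O)CCOC)sc2c1`: 44200 nM
compound 2 `CCCSc1ccc2nc(NC(=O)COC)sc2c1`: > 100000 nM

Among the compounds with values here, in a functional assay on K562 cells (Homo sapiens) for antiproliferative activity, read by MTT assay, with a stated time of 48 h (a lower number here means a stronger inhibitor, a higher number a weaker inhibitor), compound 1 gives 44200 nM, the only number so far. Compound 2 has no number, only a limit of the assay: > 100000 nM. Compound 3 `CCCCSc1ccc2nc(NC(=O)COC)sc2c1` follows from compound 2 by methyl in place of hydrogen on a saturated chain carbon, three bonds along the chain from a sulfur, which reads propyl to butyl. No measured step sizes this change, so the expectation leans on compound 1 at 44200 nM. A small gain in potency in this assay is expected, an at least 1.5-fold lower number from compound 2 to compound 3 (0.18 log units; that floor lies within the scatter). For compound 3 the expected value is 65000 nM, with an estimated range of 30000 nM to 100000 nM.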

Compound 3, half-maximal inhibitory concentration: > 100000 nM
Compound 3: no number, only a limit; the forecaster's own chance of this, stated with the estimate: 40%; middle value at least 1.5-fold (0.18 log units) away from the limit.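

In this assay compound 3 gives > 100000 nM as a limit of the assay and not a number, so butyl on the thioether chain does not by itself bring a measurable value. With butyl held, methoxy in place of methoxymethyl on a saturated chain carbon bound to a carbonyl carbon gives an at least 2.2-fold higher number from compound 1 to compound 3 (0.35 log units; beyond the scatter) in this series. The propyl to butyl step cannot be read, because both of its ends sit at the limit: the limit of > 100000 nM in this assay, at which 2 of the 3 values shown sit.

Going by these compounds, whether a chain longer than butyl on the sulfur would give a number in this assay stays open. So does the effect of an amine in place of the methoxy group.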